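Three Compounds at One Assay Limit, a Fourth Awaited

The source may hold more compounds than are shown below. What is called first, only, known or untested is meant among the compounds shown, and "the series" means these compounds.

Compound 1 `CCC(C)C1NC(=O)N(C2CCCCC2)C1=O`, compound 2 `CCC(C)C1NC(=O)N(C2CCCC2)C1=O` and compound 3 `CC(C)C1NC(=O)N(C2CCCC2)C1=O` share a core and were tested in a functional assay on CCRF-CEM cells (Homo sapiens) for inhibition; a higher number here means a weaker inhibitor, a lower number a stronger inhibitor. Compound 1 gives > 200000 nM in this assay, which is a limit of the assay and not a number. Compound 2 gives > 200000 nM, again a limit. Compound 3 gives > 200000 nM, also a limit. How the core of compound 1 differs from the core of compound 2 is not broken down here. Compound 3 differs from compound 2 by hydrogen in place of methyl on a saturated chain carbon, two bonds along the chain from a saturated ring carbon, and the resulting step is a step that the two limits leave unreadable from compound 2 to compound 3. The not yet measured compound 4 `CC(C)C1NC(=O)N(C2CCCCC2)C1=O` differs from compound 1 by the same change, (hydrogen in place of methyl on a saturated chain carbon, two bonds along the chain from a saturated ring carbon). Beside that earlier unreadable step, the step that the limit leaves unreadable from compound 1 to compound 4 is expected to be equally small, because the limit of > 200000 nM in this assay, at which 3 of the 3 values shown sit, puts every measured value at one limit and the same change within that set moved nothing that could be read. Compound 4 is therefore estimated at 300000 nM, with a range of 150000 nM to 1000000 nM, and most likely only a limit will be reported.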

Compound 4, half-maximal inhibitory concentration: > 200000 nM
Compound 4 gave a limit, no number; the forecaster's own chance of this, stated with the estimate: 90%; the middle value does not contradict the limit.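

Compound 1 and compound 4 both sit at a limit in this assay, so no step can be read between them, nor between compound 2 and compound 3. The compounds shown leave open what the change from sec-butyl to isopropyl does to inhibition, since none of them gives a number: the limit of > 200000 nM in this assay, at which 4 of the 4 values shown sit.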